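The source may report more compounds than this note shows. Statements on the series, on what has been measured and on what is new or still open speak of the compounds shown alone.

Compound 1 `CN(C)CCCOc1ccc(CN2CC[C@H](NC(=O)c3ccco3)C2)cc1` and compound 2 `CN(C)CCCOc1ccc(CN2CC[C@H](NC(=O)c3ccncc3)C2)cc1` share a core that carries one aromatic ring on a carbonyl carbon. In an assay on HEK293 cells for binding affinity to Urotensin-2 receptor (Homo sapiens), read by radioligand binding (on this read-out higher numbers stand for weaker inhibition and lower numbers for stronger inhibition), compound 1 gives only a limit of the assay, < 10000 nM. In this assay compound 2 likewise gives only a limit, < 10000 nM. The change between them, (pyridin-4-yl in place of furan-2-yl on a carbonyl carbon), gives a step that the two limits leave unreadable from compound 1 to compound 2, because the limit of < 10000 nM in this assay, at which 2 of the 3 values shown sit, hides its size. Compound 3 `CC(C)C[C@H](NC(=O)c1ccco1)C(=O)N[C@H]1CCN(Cc2ccc(OCCCN(C)C)cc2)C1` has a larger core; how it differs from the core of compound 1 is not broken down here. In this assay compound 3 gives 631 nM. Compound 4 `CC(C)C[C@H](NC(=O)c1ccncc1)C(=O)N[C@H]1CCN(Cc2ccc(OCCCN(C)C)cc2)C1` carries the same kind of change, (pyridin-4-yl in place of furan-2-yl on a carbonyl carbon). With the first step unreadable, compound 4 is expected to sit close to compound 3, a step of a 1.1-fold higher number from compound 3 to compound 4 (0.05 log units; within the scatter), and its value in this assay is estimated at 700 nM, between 150 nM and 3000 nM.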

Compound 4, inhibition constant: 2000 nM
The estimate for compound 4 lay 2.9-fold (0.46 log units) below the measured number, within the range that was stated.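

On the larger core, pyridin-4-yl in place of furan-2-yl on a carbonyl carbon gives a 3.2-fold higher number from compound 3 to compound 4 (0.50 log units; beyond the scatter) in this assay, so here the furan-2-yl compound shows the stronger inhibition. On the core of compound 1, the same change cannot be read, because the values for compound 1 and compound 2 are both limits of the assay: the limit of < 10000 nM in this assay, at which 2 of the 4 values shown sit. This leaves a single readable step, which shows what the change does on one core but not whether that effect carries over from the other.

The compounds shown leave open how other rings on that carbonyl carbon, such as phenyl or thiophen-2-yl, would read on either core. They also leave open whether a piperidine in place of the dimethylamino group would alter these results.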